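Compound 2 to compound 3: swapping the nitrogen substituent

A few compounds are considered here, and "the series" means these few. Any claim that something is new, unique, unknown or untested is made for them only; others in the source may bear on it.

In a functional assay on HeLa cells (Homo sapiens) for antiproliferative activity, read by MTT assay, with a stated time of 48 h (on this read-out higher numbers stand for weaker inhibition and lower numbers for stronger inhibition), compound 1 (`Cn1cc(-c2cnc3ccnc(N)c3c2)cn1`) gives 40800 nM. Compound 2 (`Cn1cc(-c2cnc3ccnc(NC(=O)c4cccnc4)c3c2)cn1`) gives > 50000 nM, which is a limit of the assay and not a number. Compound 2 therefore has no exact position on the scale. Going by the values given here, the one measured step that bears on the next change is an at least 1.2-fold higher number from compound 1 to compound 2 (0.08 log units; that floor lies within the scatter), with (pyridin-3-yl)carbonyl in place of hydrogen on a nitrogen on an aromatic ring. Compound 3 (`Cn1cc(-c2cnc3ccnc(NCC4CC4)c3c2)cn1`) shares the core of compound 2 but carries cyclopropylmethyl in place of (pyridin-3-yl)carbonyl on that nitrogen: cyclopropylmethyl in place of (pyridin-3-yl)carbonyl on a nitrogen on an aromatic ring. Among the compounds with values here, no measured step covers a cyclopropylmethyl group, so the expectation leans on compound 1 at 40800 nM, the only exact number available. A modest move towards a lower number is expected in this assay, and it may not clear the scatter, with another limit quite possible. The step expected here is an at least 1.6-fold lower number from compound 2 to compound 3 (0.22 log units; that floor lies within the scatter). For compound 3 the estimated value is 30000 nM, with an expected range from 9000 nM to 50000 nM.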

Compound 3, half-maximal inhibitory concentration: 7400 nM
Beside the measured number, compound 3's estimate is 4.1-fold (0.61 log units) above it, and the stated range ends above it.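

In this assay, this nitrogen on an aromatic ring turns out to be a place where a substituent can shift the read-out beyond the scatter: cyclopropylmethyl in place of hydrogen gives a 5.5-fold lower number from compound 1 to compound 3 (0.74 log units; beyond the scatter). The earlier step, with (pyridin-3-yl)carbonyl on the same nitrogen, gave only an at least 1.2-fold higher number from compound 1 to compound 2 (0.08 log units; that floor lies within the scatter), so the compounds before this one showed no clear change at this position. Exchanging one substituent for the other gives an at least 6.7-fold lower number from compound 2 to compound 3 (0.82 log units; beyond the scatter), and compound 2 stands at a limit of the assay and not a number, which makes that size a floor only: the limit of > 50000 nM in this assay, at which 1 of the 3 values shown sits.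

The three compounds cannot tell whether the lower number belongs to cyclopropylmethyl in particular or would also come with a plain ethyl group, a longer chain such as n-butyl, or a benzyl group on that nitrogen. On these data alone, it also remains open whether a smaller acyl group such as acetyl would behave like (pyridin-3-yl)carbonyl, or whether the carbonyl, the pyridine ring or both go with the weaker result in compound 2.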